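The source may report more compounds than this note shows. Statements on the series, on what has been measured and on what is new or still open speak of the compounds shown alone.

Measured so far:
compound 1 `ClCc1cccc(Cn2cnc3ncnc(Cl)c32)c1` — 6300 nM
compound 2 `ClCc1cccc(Cn2cnc3c(Cl)ncnc32)c1` — 46800 nM

In a functional assay on TK-10 cells (Homo sapiens) for cytotoxicity, read by sulforhodamine B assay, with a stated time of 48 h (a lower number here means that less compound is tolerated, a higher number that more compound is tolerated), compound 1 gives 6300 nM, the lowest of the two numbers recorded. For the measured compounds named here, compound 2 gives 46800 nM, a higher number that stands well beyond the scatter of this assay; the two compounds differ in where the chloro sits on the shared core, and no single step connects them, so their values simply show that compound 1 tolerates less compound than compound 2.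

Compound 3 `ClCc1cccc(Cn2cnc3nc(Cl)nc(Cl)c32)c1` has not yet been tested. It differs from compound 1 by chloro in place of hydrogen on an aromatic carbon, that is, a chloro in place of hydrogen on an aromatic carbon of the core. Going by the values given here, with no measured pair of this kind to lean on, the size of the step is open. A small step is expected, if anything toward a slightly lower number, but not clearly beyond the scatter: the expected change is a 1.3-fold lower number from compound 1 to compound 3 (0.10 log units; within the scatter). Compound 3 is therefore estimated at 5000 nM, within a range of 1500 nM to 16000 nM.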

Compound 3, concentration lethal to 50% of the cells: 55000 nM
Beside the measured number, compound 3's estimate is 11-fold (1.04 log units) below it; the whole stated range lies below it.
By their numbers in this assay, from the lowest: compound 1; then compounds 2 and 3 (each within the scatter of the next).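

this assay gives the first step measured on the shared core, and it is not small: a chloro in place of hydrogen on an aromatic carbon between two ring nitrogen atoms gives an 8.7-fold higher number from compound 1 to compound 3 (0.94 log units; beyond the scatter) and lies beyond the scatter. This position therefore responds to the change, and in this single pair the added chloro goes with more compound being tolerated. Nothing shown here accounts for the size or direction of the step.

From the compounds shown here alone, whether the same carbon would respond in this way to other groups stays open; an amine or a methoxy group there would show whether the higher number is specific to chloro. One pair also leaves open whether the step would hold on the core of compound 2, which lacks a measured partner with this change.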